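Working notes: from compound 3 to compound 4

The source may hold more compounds than are shown below. What is called first, only, known or untested is meant among the compounds shown, and "the series" means these compounds.

Measured compounds, read in a functional assay on HeLa cells (Homo sapiens) for cytotoxicity, read by sulforhodamine B assay, with a stated time of 48 h; a lower number here means a stronger inhibitor, a higher number a weaker inhibitor:
compound 1 `CC(=O)OC[C@H]1O[C@@H](n2cc(Cn3cc(/C=C4/C(=O)Nc5ccc(F)cc54)c4ccccc43)nn2)[C@H](OC(C)=O)[C@@H](OC(C)=O)[C@@H]1OC(C)=O` gives a limit, > 200000 nM.
compound 2 `CC(=O)OC[C@H]1O[C@@H](n2cc(CN3C(=O)/C(=C\C=C\c4ccccc4)c4ccccc43)nn2)[C@H](OC(C)=O)[C@@H](OC(C)=O)[C@@H]1OC(C)=O` gives 98100 nM.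
compound 3 `CC(=O)OC[C@H]1O[C@@H](n2cc(CN3C(=O)/C(=C/C=C/c4ccccc4)c4ccccc43)nn2)[C@H](OC(C)=O)[C@@H](OC(C)=O)[C@@H]1OC(C)=O` gives a limit, > 100000 nM.

Compound 3 stands at a limit of this assay, not at a number. Compound 1 sits at a limit as well, and only compound 2 gives a number. Within the data shown here, the one step between measured compounds, an at least 1.0-fold higher number from compound 2 to compound 3 (0.00 log units; that floor lies within the scatter), is a floor that lies within the scatter; the pair differs only in configuration as drawn (the fact that compounds 2 and 3 differ only in the configuration as drawn).

Compound 4 `CC(=O)OC[C@H]1O[C@@H](n2cc(CN3C(=O)/C(=C/c4ccc(N(C)C)cc4)c4ccccc43)nn2)[C@H](OC(C)=O)[C@@H](OC(C)=O)[C@@H]1OC(C)=O` takes the change (4-(dimethylamino)phenyl in place of 2-phenylethenyl on a double-bonded chain carbon bound to a double-bonded ring carbon). Among the measured compounds shown here, no measured step concerns an exchange of this kind: the step from compound 2 to compound 3 touches configuration only, and compound 1 differs from the others in more than one place. What compound 3 itself shows is a limit, so the starting point is uncertain. All three measured values sit at or close to the limits of this assay, which gives no ground for expecting a move beyond the scatter in either direction. The estimate for compound 4 in this assay is therefore 100000 nM, between 30000 nM and 300000 nM, and it is expected that a limit rather than a number may again be reported. The step this estimate implies, a number no higher from compound 3 to compound 4 (the limit leaves the size open), is expected to stay within the scatter.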

Compound 4, half-maximal inhibitory concentration: 26300 nM
Compound 4: the middle estimate sits 3.8-fold (0.58 log units) above what was measured; measured number outside the range, below it.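

In this assay, placing 4-(dimethylamino)phenyl in place of 2-phenylethenyl on a double-bonded chain carbon bound to a double-bonded ring carbon gives an at least 3.8-fold lower number from compound 3 to compound 4 (0.58 log units; beyond the scatter). Among these compounds, this is the first step printed as beyond the scatter, and it shows that the read-out at this position responds to an exchange of the group itself; the only earlier step, an at least 1.0-fold higher number from compound 2 to compound 3 (0.00 log units; that floor lies within the scatter), touched configuration alone and yielded a floor within the scatter. The size of the new step also remains a floor, since compound 3 stands at a limit and not at a number: the limit of > 100000 nM in this assay, at which 1 of the 4 values shown sits.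

The compounds shown do not separate the aromatic ring from the dimethylamino group, so a plain phenyl or a 4-methoxyphenyl at this place would be needed to tell whether the step goes with the ring or with the amine. As far as these compounds go, whether the configuration of the double bond counts once 4-(dimethylamino)phenyl sits at this position also stays open.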